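Swapping a Benzoyl for a Tosyl on the Shared Core

The source may report more compounds than this note shows. Statements on the series, on what has been measured and on what is new or still open speak of the compounds shown alone.

Compound 1 `CCC(=O)N(C)c1ccc2[nH]c(-c3n[nH]c4ccccc34)cc2n1`, compound 2 `CN(C(=O)c1ccccc1)c1ccc2[nH]c(-c3n[nH]c4ccccc34)cc2n1` and compound 3 `COc1cccc(C(=O)N(C)c2ccc3[nH]c(-c4n[nH]c5ccccc45)cc3n2)c1` share one core and differ only in the group on a carbonyl carbon. In a functional assay on KB cells (Homo sapiens) for antiproliferative activity, read by MTT assay, with a stated time of 72 h (on this read-out lower numbers stand for stronger inhibition and higher numbers for weaker inhibition), compound 1 gives 9300 nM, compound 2 gives 8580 nM and compound 3 gives 9010 nM. The three numbers lie within the scatter of one another: a 1.1-fold lower number from compound 1 to compound 2 (0.03 log units; within the scatter), a 1.0-fold lower number from compound 1 to compound 3 (0.01 log units; within the scatter) and a 1.1-fold higher number from compound 2 to compound 3 (0.02 log units; within the scatter). Compound 2 thus stands together with compound 1 and compound 3 rather than apart from them.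

Compound 4 `Cc1ccc(S(=O)(=O)N(C)c2ccc3[nH]c(-c4n[nH]c5ccccc45)cc3n2)cc1` carries (4-methylphenyl)sulfonyl in place of benzoyl on a nitrogen on an aromatic ring. Among the measured compounds shown here, no measured step exchanges the carbonyl for a sulfonyl; the steps from compound 1 to compound 2 and from compound 1 to compound 3 only exchanged the group on the carbonyl carbon and moved nothing beyond the scatter. On that basis compound 4 is expected to show no step beyond the scatter in this assay, with a 1.0-fold higher number from compound 2 to compound 4 (0.02 log units; within the scatter). Compound 4 is therefore estimated at 9000 nM, within a range from 3000 nM to 27000 nM.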

Compound 4, half-maximal inhibitory concentration: 9500 nM
Compound 4: middle estimate off by 1.1-fold (0.02 log units), on the low side, within the range that was stated.
By their numbers in this assay, from the lowest: compounds 2, 3, 1 and 4 (each within the scatter of the next).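

The (4-methylphenyl)sulfonyl group is the first change shown that replaces the carbonyl itself rather than only the group on it, and in this assay this exchange on a nitrogen on an aromatic ring gives a 1.1-fold higher number from compound 2 to compound 4 (0.04 log units; within the scatter) and likewise a 1.1-fold higher number from compound 3 to compound 4 (0.02 log units; within the scatter) and a 1.0-fold higher number from compound 1 to compound 4 (0.01 log units; within the scatter). At this position, then, a sulfonyl and a carbonyl give numbers within the scatter of each other across the four compounds shown, whichever group they carry. Nothing available bears on why these numbers stay together.

As far as these compounds go, it remains open whether any group on this nitrogen can move the number beyond the scatter at all. A carboxylic acid or an amine on the aromatic ring of the sulfonyl group, or a longer chain in place of that ring, would put this to the test.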